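Ester Replaces Dimethoxy Pattern on a Benzyl Ether

This account rests on a few compounds, and the source may have more. Where it says the series, first, only, none or still open, it means among the compounds named here.

Compound 1 `COc1ccc(C(c2ccc(OC(C)CN(C)C)cc2)c2cccc3ccccc23)c(OC)c1OC` gives 4340 nM in a functional assay on MDA-MB-231 cells (Homo sapiens) for inhibition, read by sulforhodamine B assay, with a stated time of 48 h; a higher number here means a weaker inhibitor, a lower number a stronger inhibitor. Compound 2 `COc1cc(COC(c2ccc(OC)c(OC)c2OC)c2cccc3ccccc23)cc(OC)c1` is reported in this assay only as a limit, > 20000 nM. That limit of > 20000 nM in this assay, at which 1 of the 2 values shown sits, is where compound 2 stands, so no numbered value is known for it. Compound 3 `COC(=O)c1ccc(COC(c2ccc(OC)c(OC)c2OC)c2cccc3ccccc23)cc1` differs from compound 2 by 4-(methoxycarbonyl)phenyl in place of 3,5-dimethoxyphenyl on a saturated chain carbon bound to an oxygen on a saturated carbon. Within the data shown here, no measured step of this kind is available, and the change is expected to stay within the scatter, a number no higher from compound 2 to compound 3 (the limit leaves the size open). Compound 3 is therefore estimated at 20000 nM in this assay, with a range from 8000 nM to 60000 nM.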

Compound 3, half-maximal inhibitory concentration: > 20000 nM
Compound 3 ended at the assay's limit; the forecaster's own chance of this, stated with the estimate: 55%; the middle value lies on the limit itself.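

No step can be read from compound 2 to compound 3, because both stand only as limits: the limit of > 20000 nM in this assay, at which 2 of the 3 values shown sit.

Whether 4-(methoxycarbonyl)phenyl or 3,5-dimethoxyphenyl gives the stronger inhibitor in this assay stays open with the compounds shown.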